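The source may report more compounds than this note shows. Statements on the series, on what has been measured and on what is new or still open speak of the compounds shown alone.

Of the compounds shown here, three sharing one core have been measured in an assay on SW1353 cells (Homo sapiens) for inhibition, read by a luciferase reporter, with stated times of 30 min and 8 h; a lower number here means a stronger inhibitor, a higher number a weaker inhibitor. Compound 1 (`O=c1sc2ccccc2n1CCCCCCN1CCN(CCCCCCn2c(=O)sc3ccccc32)CC1`) gives 410 nM, compound 2 (`O=c1sc2ccccc2n1CCCCCCN1CCN(CCn2c(=O)sc3ccccc32)CC1`) gives 2950 nM, and compound 3 (`O=c1sc2ccccc2n1CCCCCCN1CCN(CCCn2c(=O)sc3ccccc32)CC1`) gives 2400 nM. Compound 3 thus stands level with compound 2 within the scatter, while the number for compound 1 is lower than that of compound 3 by a margin beyond the scatter.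

The next compound, compound 4 (`O=c1sc2ccccc2n1CCCCCCN1CCN(CCCCn2c(=O)sc3ccccc32)CC1`), has not yet been measured. Its difference from compound 3 is a group of 11 heavy atoms (8 carbon, 1 nitrogen, 1 oxygen, 1 sulfur; one five-membered aromatic ring with 2 hetero atoms, one six-membered aromatic ring of carbon only) in place of a group of 10 heavy atoms (7 carbon, 1 nitrogen, 1 oxygen, 1 sulfur; one five-membered aromatic ring with 2 hetero atoms, one six-membered aromatic ring of carbon only), on a saturated chain carbon, three bonds along the chain from an amine nitrogen in a ring. The nearest measured precedent is the same kind of exchange, two bonds along the chain from an amine nitrogen in a ring: a 1.2-fold lower number from compound 2 to compound 3 (0.09 log units; within the scatter), a step within the scatter. Compound 1, at 410 nM, carries a longer chain at this place, which hints that a lower number may lie further along the series. Among the measured compounds shown here, no measured step connects it directly to compound 4, however, so this hint is given little weight.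

Only a small move towards a lower number is therefore expected in this assay, and none beyond the scatter. The estimated step is a 1.3-fold lower number from compound 3 to compound 4 (0.12 log units; within the scatter). For compound 4 the expected value is 1800 nM, with an estimated range of 700 nM to 3500 nM.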

Compound 4, half-maximal inhibitory concentration: 830 nM
Beside the measured number, compound 4's estimate is 2.2-fold (0.34 log units) above it; the measured number falls inside the stated range.
By their numbers in this assay, from the lowest: compound 1; then compound 4; then compounds 3 and 2 (each within the scatter of the next).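

In this assay, among the compounds shown here, this lengthening of the chain is the first to give a change beyond the scatter: a 2.9-fold lower number from compound 3 to compound 4 (0.46 log units; beyond the scatter), whereas the same kind of exchange one carbon closer to the amine nitrogen in a ring gave a 1.2-fold lower number from compound 2 to compound 3 (0.09 log units; within the scatter), a step within the scatter. The two exchanges together amount to a 3.6-fold lower number from compound 2 to compound 4 (0.55 log units; beyond the scatter), so the gain in this short series appears at the position three bonds along the chain from an amine nitrogen in a ring, and it does not yet reach the level of the longest chain shown, with a 2.0-fold higher number from compound 1 to compound 4 (0.31 log units; beyond the scatter) still separating the two compounds. No measurement is available that would explain why the added carbon matters at this position and not at the one before it.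

The compounds shown leave open whether the number would keep falling with a chain longer than that of compound 1, or would turn back up. They also do not tell whether an ether oxygen or an amide within the chain would be tolerated at this position.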